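Swapping the amino-bearing ring for a trimethoxyphenyl

The source may hold more compounds than are shown below. What is called first, only, known or untested is meant among the compounds shown, and "the series" means these compounds.

Measured so far:
- Compound 1, `COc1cc(N(Cc2ccccc2)C(=O)CSc2nc3ccccc3s2)cc(OC)c1OC`: 54500 nM
- Compound 2, `COc1ccc(CN(C(=O)CSc2nc3ccccc3s2)c2cc(OC)c(OC)c(OC)c2)cc1C`: 17100 nM
- Compound 3, `COc1ccc(CN(C(=O)CSc2nc3ccccc3s2)c2cc(OC)c(OC)c(OC)c2)cc1N`: 491 nM

In a functional assay on HCT-116 cells (Homo sapiens) for antiproliferative activity, read by MTT assay, with a stated time of 48 h (a higher number here means a weaker inhibitor, a lower number a stronger inhibitor), compound 3 gives the lowest number of the three, with a 35-fold lower number from compound 2 to compound 3 (1.54 log units; beyond the scatter) and a 110-fold lower number from compound 1 to compound 3 (2.05 log units; beyond the scatter). Compound 4, `COc1cc(CN(C(=O)CSc2nc3ccccc3s2)c2cc(OC)c(OC)c(OC)c2)cc(OC)c1OC`, differs from compound 3 in one place: 3,4,5-trimethoxyphenyl in place of 3-amino-4-methoxyphenyl on a saturated chain carbon bound to an amide-type nitrogen. Among the compounds with values here, no measured step covers a trimethoxyphenyl here. The nearest guides are a 3.2-fold lower number from compound 1 to compound 2 (0.50 log units; beyond the scatter), a gain from adding methoxy and methyl to the bare phenyl, and a 35-fold lower number from compound 2 to compound 3 (1.54 log units; beyond the scatter), a much larger gain tied to the amino group. Compound 4 keeps extra methoxy groups but loses that amino group, so a substantial rise toward the region of compound 2 is expected, a 20-fold higher number from compound 3 to compound 4 (1.31 log units; beyond the scatter). Compound 4 is therefore estimated at 10000 nM, within 2000 nM to 50000 nM.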

Compound 4, half-maximal inhibitory concentration: 65300 nM
Beside the measured number, compound 4's estimate is 6.5-fold (0.81 log units) below it, and the stated range ends below it.
By their numbers in this assay, from the lowest: compound 3; then compound 2; then compounds 1 and 4 (each within the scatter of the next).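

In this assay extra methoxy groups do not stand in for the amino group, with a 130-fold higher number from compound 3 to compound 4 (2.12 log units; beyond the scatter) and even a 3.8-fold higher number from compound 2 to compound 4 (0.58 log units; beyond the scatter) against the methyl-bearing ring. The 3,4,5-trimethoxyphenyl ring also cannot be told apart from bare phenyl (a 1.2-fold higher number from compound 1 to compound 4 (0.08 log units; within the scatter)), so more methoxy groups on this ring do not by themselves give a stronger inhibitor. No available evidence explains this behaviour.

Going by these compounds, what stays open is whether the strength of compound 3 belongs to the amino group alone, or would also appear with a hydroxyl or a dimethylamino group on that ring.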